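Adding a third methoxy group to a pyrazoline sulfonamide

This account rests on a few compounds, and the source may have more. Where it says the series, first, only, none or still open, it means among the compounds named here.

Compound 2 `COc1ccc(C2CC(c3cc(Cl)c(C)cc3O)=NN2c2ccc(S(N)(=O)=O)cc2)cc1OC` gives the highest of the two numbers in a functional assay on BT-549 cells (Homo sapiens) for antiproliferative activity, with a stated time of 48 h (on this read-out higher numbers stand for lower toxicity in this test and lower numbers for higher toxicity in this test), with 95600 nM; its nearest neighbour, compound 1 `Cc1cc(O)c(C2=NN(c3ccc(S(N)(=O)=O)cc3)C(/C=C/c3ccccc3)C2)cc1Cl`, gives 54500 nM, and a 1.8-fold higher number from compound 1 to compound 2 (0.24 log units; within the scatter). Compound 3 `COc1ccc(C2CC(c3cc(Cl)c(C)cc3O)=NN2c2ccc(S(N)(=O)=O)cc2)c(OC)c1OC` differs from compound 2 by methoxy in place of hydrogen on an aromatic carbon. Within the data shown here, no measured step in this assay involves such an added methoxy group, and the one step that is known stays within the scatter, so no shift beyond the scatter is expected for a 1.1-fold lower number from compound 2 to compound 3 (0.03 log units; within the scatter). Compound 3 is therefore estimated at 90000 nM in this assay, within a range from 35000 nM to 250000 nM.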

Compound 3, concentration lethal to 50% of the cells: 27200 nM
For compound 3 the middle estimate is 3.3-fold (0.52 log units) above the measured one; measured number outside the range, below it.
By their numbers in this assay, from the lowest: compounds 3, 1 and 2 (each within the scatter of the next, the first and the last beyond it).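

The methoxy group added on this aromatic carbon, ortho to a large group, gives a 3.5-fold lower number from compound 2 to compound 3 (0.55 log units; beyond the scatter) in this assay. This is the only step among these compounds that lies beyond the scatter, and it points towards higher toxicity in this test. Set against the 2-phenylethenyl compound, the 2,3,4-trimethoxyphenyl group gives a 2.0-fold lower number from compound 1 to compound 3 (0.30 log units; within the scatter), and nothing available accounts for the shift at this position.

Going by these compounds, whether the shift is specific to methoxy remains open, as a hydroxyl, an ethoxy group or a fluorine on this carbon could give a different number. On these data alone, it is also open whether the same methoxy group would give a similar step on the 2-phenylethenyl side of the series.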